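Side-chain change from compound 2 to compound 3

The source may report more compounds than this note shows. Statements on the series, on what has been measured and on what is new or still open speak of the compounds shown alone.

Measured in an ADME assay on microsomes from liver (Rattus norvegicus) for metabolic stability, read by LC-MS, with a stated time of 10 min, tested at 0.5 uM; on this read-out higher numbers stand for a more stable compound and lower numbers for a less stable compound:
- compound 1 `CCN1CCN(CCCN(C[C@H]2Cc3ccccc3CN2)[C@H]2CCCc3cccnc32)CC1`: 1%
- compound 2 `c1ccc2c(c1)CN[C@@H](CN(CCN1CCNCC1)[C@H]1CCCc3cccnc31)C2`: 62%

Compound 2 holds the higher of the two numbers in this assay. The next change leads to compound 3 `NC(=O)N1CCN(CCCN(C[C@H]2Cc3ccccc3CN2)[C@H]2CCCc3cccnc32)CC1`: (4-carbamoylpiperazin-1-yl)methyl in place of piperazin-1-yl on a saturated chain carbon, two bonds along the chain from an amine nitrogen. This puts (4-carbamoylpiperazin-1-yl)methyl in place of piperazin-1-yl on a saturated chain carbon, two bonds along the chain from an amine nitrogen. Among the compounds with values here, one measured step bears on it: a number 61 percentage points higher from compound 1 to compound 2 (beyond the scatter), a large step beyond the scatter, with piperazin-1-yl entering where compound 1 carried (4-ethylpiperazin-1-yl)methyl. The new group runs the opposite way and resembles that of compound 1, with carbamoyl in place of ethyl. Within the data shown here, no measured compound shows what that swap does. A clear fall is expected, probably smaller than the measured step. The expected change is a number 37 percentage points lower from compound 2 to compound 3 (beyond the scatter). For compound 3 the estimate is 25%, with an expected range from 5% to 55%.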

Compound 3, percent of the compound remaining: 4%
Compound 3: middle estimate off by 21 percentage points, on the high side; the measured number lies below the stated range.
By their numbers in this assay, from the lowest: compounds 1 and 3 (each within the scatter of the next); then compound 2.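

In this assay, carbamoyl in place of ethyl on an amine nitrogen in a ring gives a number 3 percentage points higher from compound 1 to compound 3 (within the scatter), so the low number of compound 1 does not depend on the ethyl group alone. The (4-carbamoylpiperazin-1-yl)methyl group in place of piperazin-1-yl gives a number 58 percentage points lower from compound 2 to compound 3 (beyond the scatter), which shows that a second substituted group at this position, on a saturated chain carbon, two bonds along the chain from an amine nitrogen, also goes with a low number. Among these three compounds, only compound 2 holds a high number, and it differs from both others in the chain and in the ring nitrogen substituent together.

From the compounds shown here alone, a (piperazin-1-yl)methyl group or a 4-ethylpiperazin-1-yl group would separate those two changes, so it remains open which of them carries the step. No measurement here gives a cause for these numbers.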